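The source may report more compounds than this note shows. Statements on the series, on what has been measured and on what is new or still open speak of the compounds shown alone.

Measured so far in a functional assay on HT-29 cells (Homo sapiens) for cytotoxicity, read by MTT assay, with a stated time of 72 h; on this read-out lower numbers stand for stronger inhibition of growth and higher numbers for weaker inhibition of growth:
- compound 1 `N#C/C(=C/c1ccc2ccccc2c1)C(=O)c1ccc[nH]1` gives < 10000 nM (a limit)
- compound 2 `Cc1ccc(/C=C(/C#N)C(=O)c2ccc[nH]2)cc1` gives 14000 nM (a number)
- compound 3 `N#C/C(=C/c1ccc([N+](=O)[O-])cc1)C(=O)c1ccc[nH]1` gives < 10000 nM (a limit)

Compound 3 is known only through the limit < 10000 nM and has no number. The series offers the limit of < 10000 nM in this assay, at which 2 of the 3 values shown sit, as its main reference point.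

Compound 4 `COc1ccc(/C=C(/C#N)C(=O)c2ccc[nH]2)cc1` carries methoxy in place of nitro on an aromatic carbon (methoxy in place of nitro, para to a large group). Among the compounds with values here, the only measured step at this place is an at least 1.4-fold lower number from compound 2 to compound 3 (0.14 log units; that floor lies within the scatter) and it gives only a floor. Compound 2, with methyl there, gives 14000 nM and so a small move toward a higher number is expected, possibly none beyond the scatter, with an at least 1.1-fold higher number from compound 3 to compound 4 (0.04 log units; that floor lies within the scatter) as the estimated step. Compound 4 is estimated at 11000 nM with 4000 nM to 25000 nM as the expected range.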

Compound 4, concentration for 50% growth inhibition: < 10000 nM
Compound 4: only a limit was reported; the forecaster's own chance of this, stated with the estimate: 45%; at least 1.1-fold (0.04 log units) between middle value and limit.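

In this assay compound 4 gives < 10000 nM, a limit and not a number. Methoxy in place of methyl, para to a large group, gives an at least 1.4-fold lower number from compound 2 to compound 4 (0.14 log units; that floor lies within the scatter), so this floor does not separate the two groups. Methoxy now joins nitro at the same limit, leaving methyl as the only group with a number at this position: the limit of < 10000 nM in this assay, at which 3 of the 4 values shown sit.

From the compounds shown here alone, the step between the limits of compound 3 and compound 4 cannot be read, so any difference between nitro and methoxy stays open. Going by these compounds, how an amine or a carboxylic acid on this aromatic carbon would read also remains open.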